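Replacing 2-cyanophenyl on the ring amine: expected cytotoxicity

This account rests on a few compounds, and the source may have more. Where it says the series, first, only, none or still open, it means among the compounds named here.

Compound 1 `O=c1nc(N2CC[C@H](c3ccccc3)[C@@H](O)C2)sc2c([N+](=O)[O-])cc(C(F)(F)F)cc12` in a toxicity assay on HeLa cells (Homo sapiens) for cytotoxicity, read by colorimetric assay, with a stated time of 72 h (on this read-out lower numbers stand for higher toxicity in this test and higher numbers for lower toxicity in this test), gives 73100 nM. Compound 2 `N#Cc1ccccc1N1CCN(c2nc(=O)c3cc(C(F)(F)F)cc([N+](=O)[O-])c3s2)CC1` reaches only a limit of this assay, > 108000 nM, not a number. Among the values known, compound 2 therefore sits at the low-toxicity edge, (the limit of > 108000 nM in this assay, at which 1 of the 2 values shown sits). Compound 3 `O=C(CN1CCN(c2nc(=O)c3cc(C(F)(F)F)cc([N+](=O)[O-])c3s2)CC1)NCc1ccccc1` differs from compound 2 by (benzylcarbamoyl)methyl in place of 2-cyanophenyl on an amine nitrogen in a ring. Going by the values given here, no step between measured compounds that differ in one place is available, so no direction beyond the scatter is expected in this assay. Compound 3 is expected to give 100000 nM, between 50000 nM and 200000 nM. The implied step an at least 1.0-fold lower number from compound 2 to compound 3 (0.03 log units; that floor lies within the scatter) is expected to stay within the scatter, and a limit again is likely.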

Compound 3, half-maximal cytotoxic concentration: 57100 nM
The estimate for compound 3 lay 1.8-fold (0.24 log units) above the measured number, and the stated range covers the measured number.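

Going by these compounds alone, replacing 2-cyanophenyl with (benzylcarbamoyl)methyl on this amine nitrogen in a ring gives an at least 1.8-fold lower number from compound 2 to compound 3 (0.27 log units; that floor lies within the scatter) in this assay and, with compound 3, the first readable number for this position. Compound 2 stands at a limit of the assay, not a number, so the step is only a floor: the limit of > 108000 nM in this assay, at which 1 of the 3 values shown sits.

As far as these compounds go, the true size of the step stays open. Also open, from the compounds shown here alone, is whether an amine, a carboxylic acid or a longer chain on this nitrogen would move the number beyond the scatter.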